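Aryl exchange at the chain of compound 1

The source may hold more compounds than are shown below. What is called first, only, known or untested is meant among the compounds shown, and "the series" means these compounds.

Measured so far:
compound 1 `COc1cc2ncnc(Nc3ccc(F)c(Cl)c3)c2cc1NC(=O)/C=C/c1ccc(F)cc1Cl` — 32700 nM
compound 2 `COc1ccc(/C=C/C(=O)Nc2cc3c(Nc4ccc(F)c(Cl)c4)ncnc3cc2O[C@H]2CCOC2)c(OC)c1OC` — 7670 nM

Within the data shown here, in a functional assay on PC-3 cells (Homo sapiens) for cytotoxicity, read by MTT assay, with a stated time of 72 h (a lower number here means a stronger inhibitor, a higher number a weaker inhibitor), compound 1 gives 32700 nM, the highest of the two numbers measured so far. Compound 2 gives 7670 nM, a lower number that lies beyond the scatter; compound 2 differs from compound 1 in more than one place, so only the two values themselves can be set side by side, not a single step.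

Compound 3, `COc1cc2ncnc(Nc3ccc(F)c(Cl)c3)c2cc1NC(=O)/C=C/c1cc(OC)c(OC)c(OC)c1`, is not yet measured. It differs from compound 1 by 3,4,5-trimethoxyphenyl in place of 2-chloro-4-fluorophenyl on a double-bonded chain carbon bound to a double-bonded chain carbon. Among the measured compounds shown here, no pair of measured compounds isolates this change. For the measured compounds named here, the only hint is that compound 2, which also carries a methoxy-bearing ring on a double-bonded chain carbon, gives the lower of the two values, 7670 nM, against 32700 nM for compound 1.

On that basis a step to a lower number is expected from compound 1 to compound 3, a 2.7-fold lower number from compound 1 to compound 3 (0.44 log units; beyond the scatter), with a size that may or may not clear the scatter. Compound 3 is expected to give 12000 nM, with a range from 4000 nM to 35000 nM.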

Compound 3, half-maximal inhibitory concentration: 38200 nM
For compound 3 the middle estimate is 3.2-fold (0.50 log units) below the measured one, and the stated range ends below it.
By their numbers in this assay, from the lowest: compound 2; then compounds 1 and 3 (each within the scatter of the next).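

In this assay, among these compounds, the exchange of 2-chloro-4-fluorophenyl for 3,4,5-trimethoxyphenyl on a double-bonded chain carbon bound to a double-bonded chain carbon is a 1.2-fold higher number from compound 1 to compound 3 (0.07 log units; within the scatter) and is the only single-place step so far. At this position the two aryl groups therefore cannot be told apart in this read-out, although the entering group has 12 heavy atoms against 8 and 3 hydrogen-bond acceptors against 0, and a methoxy-bearing ring on this chain carbon is not by itself tied to a lower number. Nothing in hand speaks to why the two aryl groups give matching values.

Compound 2 gives 7670 nM and differs from compound 1 in more than one place, so that value stays tied to no single change. Open questions are whether a non-aryl group on this chain carbon, such as a dimethylamino group or a carboxylic acid, would move the number beyond the scatter, and whether the same aryl exchange would behave alike on the core of compound 2.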